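The compounds below may be only part of what the source reports. "The series", "measured", "known", "first", "only" and "open" are said of these compounds alone.

Measured compounds:
compound 1, `COc1ccc(-c2ccc(-c3ccc(C(=N)N)cc3)s2)cc1`, gives 1000 nM in a functional assay on RXF 393 cells (Homo sapiens) for inhibition, read by sulforhodamine B assay, with a stated time of 48 h; a lower number here means a stronger inhibitor of growth, a higher number a weaker inhibitor of growth;
compound 2, `N=C(N)c1ccc(-c2ccc(-c3cc(Cl)cc(Cl)c3)s2)cc1`, has "not determined" (no result reported) in this assay;
compound 3, `COc1cc(OC)cc(-c2ccc(-c3ccc(C(=N)N)c(F)c3)s2)c1`, gives 449 nM in this assay.

Of the two numbers available, compound 1 stands at the highest, that is the weaker end; compound 3 gives a lower number, and the gap between them lies beyond the usual scatter. Compound 2 contributes no number.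

Compound 4, `COc1ccc(-c2ccc(-c3ccc(C(=N)N)c(F)c3)s2)cc1`, is not yet tested. It differs from compound 1 by a single change: fluoro in place of hydrogen on an aromatic carbon. Within the data shown here, no pair of measured compounds shows this change alone. Compound 3 also carries fluoro, but it differs from compound 1 in a second place, so its value is only a hint. A small step toward a lower number is expected from compound 1 to compound 4, a 1.7-fold lower number from compound 1 to compound 4 (0.22 log units; within the scatter), hardly beyond the scatter. Compound 4 is therefore estimated at 600 nM, within 250 nM to 1500 nM.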

Compound 4, concentration for 50% growth inhibition: 4680 nM
For compound 4 the middle estimate is 7.8-fold (0.89 log units) below the measured one; measured number outside the range, above it.
By their numbers in this assay, from the lowest: compound 3; then compound 1; then compound 4.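

In this assay, among these compounds, fluoro in place of hydrogen on an aromatic carbon, ortho to a group of 3 heavy atoms, gives a 4.7-fold higher number from compound 1 to compound 4 (0.67 log units; beyond the scatter), the first direct reading of this change. On the core of compound 1, this single added fluorine atom therefore weakens growth inhibition rather than strengthening it. Nothing measured here accounts for the loss. From the compounds shown here alone, whether an amine or a nitrile at this position would also weaken growth inhibition remains open. So does whether fluoro on another aromatic carbon would give a similar step.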